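Aryl variation on the imine carbon in a cytotoxicity series

The source may report more compounds than this note shows. Statements on the series, on what has been measured and on what is new or still open speak of the compounds shown alone.

Three compounds of this series have been run in a functional assay on NCI-H460 cells (Homo sapiens) for cytotoxicity, read by MTT assay, with a stated time of 72 h; a lower number here means a stronger inhibitor, a higher number a weaker inhibitor. Compound 1 `CN(C)CCn1cnnc1-c1cc(Oc2ccc(NC(=O)N/N=C/c3ccc(Cl)cc3Cl)cc2F)ccn1` gives 130 nM; compound 2 `CN(C)CCn1cnnc1-c1cc(Oc2ccc(NC(=O)N/N=C/c3c(Cl)cccc3Cl)cc2F)ccn1` gives 350 nM; compound 3 `CN(C)CCn1cnnc1-c1cc(Oc2ccc(NC(=O)N/N=C/c3ccc(O)c(Br)c3)cc2F)ccn1` gives 430 nM. On these numbers compound 2 stands second highest of the three, nearest compound 3 and furthest from compound 1.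

The unmeasured compound 4 `CN(C)CCn1cnnc1-c1cc(Oc2ccc(NC(=O)N/N=C/c3ccccc3O[N+](=O)[O-])cc2F)ccn1` differs from compound 2 by 2-(nitrooxy)phenyl in place of 2,6-dichlorophenyl on a carbon with a double bond to nitrogen. Both measured steps away from compound 2 change the same aryl group on that carbon: a 2.7-fold higher number from compound 1 to compound 2 (0.43 log units; beyond the scatter) and a 1.2-fold higher number from compound 2 to compound 3 (0.09 log units; within the scatter). The wider pair shows a 3.3-fold higher number from compound 1 to compound 3 (0.52 log units; beyond the scatter). So aryl replacement at this position has given only modest movements, and none of the measured aryl groups matches the 2-(nitrooxy)phenyl group. The expected step in this assay is therefore small, a 1.2-fold lower number from compound 2 to compound 4 (0.07 log units; within the scatter), with direction uncertain. Compound 4 is estimated at 300 nM, within a range of 110 nM to 850 nM.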

Compound 4, half-maximal inhibitory concentration: 1270 nM
For compound 4 the middle estimate is 4.2-fold (0.63 log units) below the measured one; measured number above the stated range.
By their numbers in this assay, from the lowest: compound 1; then compounds 2 and 3 (each within the scatter of the next); then compound 4.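

In this assay, among these compounds, the carbon with a double bond to nitrogen proves more sensitive to the aryl group than the earlier compounds showed, with the largest step in the set at a 9.8-fold higher number from compound 1 to compound 4 (0.99 log units; beyond the scatter). The 2-(nitrooxy)phenyl group also sits clearly apart from the other two aryl groups, with a 3.6-fold higher number from compound 2 to compound 4 (0.56 log units; beyond the scatter) and a 3.0-fold higher number from compound 3 to compound 4 (0.47 log units; beyond the scatter), so compound 4 is the weakest of the four, all its steps lying beyond the scatter. Nothing at hand explains this loss.

From the compounds shown here alone, it remains open whether the loss belongs to the nitrooxy group itself or to any aryl group without halogen, since compound 3 carries bromine and compounds 1 and 2 carry chlorine. A plain phenyl, a nitrophenyl or a methoxyphenyl group on the same carbon would separate these readings.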